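A few compounds are considered here, and "the series" means these few. Any claim that something is new, unique, unknown or untested is made for them only; others in the source may bear on it.

Working notes on the series. Of the compounds shown here, three are measured so far. Compound 1 `Cc1ccc(-c2nn(-c3ccccc3)cc2-c2nc3ccccc3n2S(=O)(=O)c2ccc(Cl)cc2)cc1` gives 5520 nM in a functional assay on HepG2 cells (Homo sapiens) for antiproliferative activity, read by MTT assay, with a stated time of 24 h; on this read-out lower numbers stand for stronger inhibition and higher numbers for weaker inhibition. Compound 2 `Cc1ccc(-c2nn(-c3ccccc3)cc2-c2nc3ccccc3n2S(=O)(=O)c2ccc(Br)cc2)cc1` gives 3040 nM in this assay; its structural difference from compound 1 is bromo in place of chloro on an aromatic carbon, and the step is a 1.8-fold lower number from compound 1 to compound 2 (0.26 log units; within the scatter). Compound 3 `O=S(=O)(c1ccc(Cl)cc1)n1c(-c2cn(-c3ccccc3)nc2-c2ccc(F)cc2)nc2ccccc21` gives 4230 nM in this assay; its core differs from the core of compound 1 by fluoro in place of methyl on an aromatic carbon, with the step of a 1.3-fold lower number from compound 1 to compound 3 (0.12 log units; within the scatter). All three values sit within the usual scatter of one another, so no order among them is claimed.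

Compound 4 `O=S(=O)(c1ccc(Br)cc1)n1c(-c2cn(-c3ccccc3)nc2-c2ccc(F)cc2)nc2ccccc21` is not yet measured. It differs from compound 3 by bromo in place of chloro on an aromatic carbon. This is the same change already made from compound 1 to compound 2, occurring twice in the set, and the place described for both is the same word for word. The expectation for compound 4 in this assay rests on compound 3 at 4230 nM and on the earlier step of a 1.8-fold lower number from compound 1 to compound 2 (0.26 log units; within the scatter), which stayed within the scatter. The step expected from compound 3 to compound 4 is a 1.5-fold lower number from compound 3 to compound 4 (0.18 log units; within the scatter), of similar size. Compound 4 is estimated at 2800 nM, with a likely range from 1300 nM to 6000 nM.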

Compound 4, half-maximal inhibitory concentration: 2550 nM
Compound 4: middle estimate off by 1.1-fold (0.04 log units), on the high side; the measured number falls inside the stated range.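

In this assay, bromo in place of chloro gives a 1.7-fold lower number from compound 3 to compound 4 (0.22 log units; within the scatter), and this reading agrees with the earlier one: the same change on two cores in this assay, a 1.8-fold lower number (0.26 log units; within the scatter) from compound 1 to compound 2 and a 1.7-fold lower number (0.22 log units; within the scatter) from compound 3 to compound 4, 1.1-fold (0.04 log units) apart, within the scatter of two such steps. Fluoro in place of methyl gives a 1.2-fold lower number from compound 2 to compound 4 (0.08 log units; within the scatter), which likewise agrees with its earlier reading: the same change on two cores in this assay, a 1.3-fold lower number (0.12 log units; within the scatter) from compound 1 to compound 3 and a 1.2-fold lower number (0.08 log units; within the scatter) from compound 2 to compound 4, 1.1-fold (0.04 log units) apart, within the scatter of two such steps. Each change therefore reads alike on the two cores where it can be followed, but all four steps lie within the scatter, so this shows neither that either change truly moves the number nor that the agreement would hold on any other core.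

The compounds shown leave open whether an amine, a carboxylic acid or a methoxy group in place of the chloro or bromo of the (4-chlorophenyl)sulfonyl and (4-bromophenyl)sulfonyl groups would give a step beyond the scatter. They also leave open whether such a step, once found, would carry from one core to another as these two changes do.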